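This account rests on a few compounds, and the source may have more. Where it says the series, first, only, none or still open, it means among the compounds named here.

Compound 1 `CO[C@@H]1[C@@H](O)[C@@H](O)[C@H](Oc2ccc3c(c2C)OC(=O)C(n2cc(-c4ccccc4)nn2)C3)OC1(C)C` carries a phenyl on the triazole of a shared core, and compound 2 `COc1ccc(-c2cn(C3Cc4ccc(O[C@@H]5OC(C)(C)[C@H](OC)[C@@H](O)[C@H]5O)c(C)c4OC3=O)nn2)cc1` is the same molecule with a methoxy in place of hydrogen on an aromatic carbon. In a functional assay on MCF7 cells (Homo sapiens) for antiproliferative activity (on this read-out lower numbers stand for stronger inhibition and higher numbers for weaker inhibition), compound 1 gives 64400 nM. In this assay compound 2 gives > 100000 nM, which is a limit of the assay and not a number. Compound 2 thus stands at the weak end of what has been measured here, sitting at the limit of > 100000 nM in this assay, at which 1 of the 2 values shown sits. The step of an at least 1.5-fold higher number from compound 1 to compound 2 (0.19 log units; that floor lies within the scatter) is known only as a floor. Compound 3 `COc1cccc(-c2cc(-c3cn(C4Cc5ccc(O[C@@H]6OC(C)(C)[C@H](OC)[C@@H](O)[C@H]6O)c(C)c5OC4=O)nn3)ccc2OC)c1` differs from compound 2 by 3-methoxyphenyl in place of hydrogen on an aromatic carbon. Going by the values given here, the single measured step concerns a different change and is itself only a floor, so it offers no firm direction for this new step. Compound 3 is expected to stay near the limit, an estimated step that the limit leaves unreadable from compound 2 to compound 3. Compound 3 is therefore estimated at 150000 nM, within 40000 nM to 500000 nM.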

Compound 3, half-maximal inhibitory concentration: 13200 nM
Compound 3: middle estimate off by 11-fold (1.06 log units), on the high side; the whole stated range lies above it.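

In this assay, placing a 3-methoxyphenyl on this aromatic carbon, ortho to a methoxy group and meta to a large group, gives an at least 7.5-fold lower number from compound 2 to compound 3 (0.87 log units; beyond the scatter). This is the first change shown whose effect clearly lies beyond the scatter, and it shows that this position on the aromatic ring can carry a second aromatic ring while inhibition grows stronger. The true size of the gain stays unknown because compound 2 is held only as a limit of the assay: the limit of > 100000 nM in this assay, at which 1 of the 3 values shown sits.

The compounds shown leave open whether the added ring would give the same gain without its own methoxy group. They also leave open how a different group on that ring, such as an amine or a carboxylic acid, would read in this assay.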